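Chloro at the distal phenyl on an acetylated sulfonamide core

The compounds below may be only part of what the source reports. "The series", "measured", "known", "first", "only" and "open" are said of these compounds alone.

Compound 1 (`NS(=O)(=O)c1ccc(-n2nc(-c3ccccc3)cc2-c2cc(O)ccc2O)cc1`) and compound 2 (`NS(=O)(=O)c1ccc(-n2nc(-c3ccc(Cl)cc3)cc2-c2cc(O)ccc2O)cc1`) differ by one change, (chloro in place of hydrogen on an aromatic carbon). In a functional assay on cells (Leukemia cell, Homo sapiens) for cytotoxicity, read by sulforhodamine B assay, with a stated time of 48 h (a higher number here means a weaker inhibitor of growth, a lower number a stronger inhibitor of growth), compound 1 gives 100000 nM, and compound 2 gives 61400 nM; the step is a 1.6-fold lower number from compound 1 to compound 2 (0.21 log units; within the scatter). Compound 3 (`CC(=O)NS(=O)(=O)c1ccc(-n2nc(-c3ccccc3)cc2-c2cc(O)ccc2O)cc1`) carries a different core, and the difference from compound 1 is acetyl in place of hydrogen on a sulfonamide nitrogen. In this assay compound 3 gives 100000 nM, and the step from its parent is no change at the digits printed from compound 1 to compound 3 (within the scatter). Compound 3 thus stands level with compound 1, and the two together are the highest numbers of the three.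

Compound 4 (`CC(=O)NS(=O)(=O)c1ccc(-n2nc(-c3ccc(Cl)cc3)cc2-c2cc(O)ccc2O)cc1`) has not been measured. Going by the values given here, it differs from compound 3 by chloro in place of hydrogen on an aromatic carbon, which is the same change as the one from compound 1 to compound 2: the two place descriptions read alike, so the change is the same, laid on the acetylated core instead of the free sulfonamide. Among the compounds with values here, the one occurrence of this change that has been measured gave only a small step, within the scatter, and there is no second occurrence to say whether the acetyl group alters it. The expectation for compound 4 therefore rests on that single step, a 1.6-fold lower number from compound 1 to compound 2 (0.21 log units; within the scatter), and on compound 3 at 100000 nM. Compound 4 is expected to show a step of a 1.5-fold lower number from compound 3 to compound 4 (0.19 log units; within the scatter) in this assay. The estimated value for compound 4 is 65000 nM, with a range expected from 30000 nM to 100000 nM.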

Compound 4, concentration for total growth inhibition: 92600 nM
For compound 4 the middle estimate is 1.4-fold (0.15 log units) below the measured one; measured number inside the range.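

Set on the acetylated core, chloro in place of hydrogen gives a 1.1-fold lower number from compound 3 to compound 4 (0.03 log units; within the scatter) in this assay, and the same change on the core of compound 1 agrees with it: the same change on two cores in this assay, a 1.6-fold lower number (0.21 log units; within the scatter) from compound 1 to compound 2 and a 1.1-fold lower number (0.03 log units; within the scatter) from compound 3 to compound 4, 1.5-fold (0.18 log units) apart, within the scatter of two such steps. Acetyl in place of hydrogen on the sulfonamide nitrogen, read on the chlorinated pair, gives a 1.5-fold higher number from compound 2 to compound 4 (0.18 log units; within the scatter), and this too agrees with its earlier occurrence: the same change on two cores in this assay, no change at the digits printed (within the scatter) from compound 1 to compound 3 and a 1.5-fold higher number (0.18 log units; within the scatter) from compound 2 to compound 4, 1.5-fold (0.18 log units) apart, within the scatter of two such steps. Going by these compounds alone, each change therefore carries from one core to the other without a difference that can be told from the scatter, but all of these steps are themselves within the scatter, so the agreement is between steps too small to read and does not show that a step of real size would carry over, and each change has been seen on only two cores.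

The compounds shown leave open whether an amine or a methoxy group in place of the chloro, or a longer acyl chain in place of the acetyl, would give a step beyond the scatter in this assay. They also leave open what methoxy groups in place of the two hydroxyl groups would do on either core, and whether the chloro and acetyl changes would then still agree.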